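A Methoxyphenyl Swap on the Double-Bonded Chain

A few compounds are considered here, and "the series" means these few. Any claim that something is new, unique, unknown or untested is made for them only; others in the source may bear on it.

Measured in a functional assay on the whole organism (strain Kunming) with Mus musculus as the target, in the formalin test, with a stated time of 0.5 h; a lower number here means that less compound is needed, a higher number that more compound is needed for the effect:
Compound 1 `COc1cc(OC)c(OC)cc1/C=C/COC(=O)/C=C/c1c(OC)ccc(OC)c1OC`: <= 80 mg/kg (a limit)
Compound 2 `COc1cc(OC)c(OC)cc1/C=C/COC(=O)/C=C/c1ccccc1C(F)(F)F`: 123 mg/kg

Among the measured compounds shown here, compound 2 stands alone so far with 123 mg/kg, the only actual number in this assay. Compound 1 has a limit and no exact number. For the measured compounds named here, the two compounds differ in more than one place, so no measured step isolates a single change.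

Compound 3 `COc1ccc(/C=C/C(=O)OC/C=C/c2cc(OC)c(OC)cc2OC)cc1` has 4-methoxyphenyl in place of 2-(trifluoromethyl)phenyl on a double-bonded chain carbon bound to a double-bonded chain carbon. A slightly smaller dose is expected, though nothing beyond the usual scatter. This expectation rests on compound 1 , which also carries methoxy groups at this place and has the limit <= 80 mg/kg. The expected step is a 1.2-fold lower number from compound 2 to compound 3 (0.09 log units; within the scatter). For compound 3 the estimated value is 100 mg/kg, with an expected range from 50 mg/kg to 200 mg/kg.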

Compound 3, dose for half-maximal effect: 122 mg/kg
Compound 3: the middle estimate sits 1.2-fold (0.09 log units) below what was measured; low and high end bracket the measured number.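

In this assay, placing 4-methoxyphenyl in place of 2-(trifluoromethyl)phenyl on a double-bonded chain carbon bound to a double-bonded chain carbon gives a 1.0-fold lower number from compound 2 to compound 3 (0.00 log units; within the scatter). Among the compounds shown here, this is the first step at this place that can be read as a single change, and it shows that this assay does not separate the two groups, even though a group with fluorine and no hydrogen-bond acceptor gives way to one with oxygen and one hydrogen-bond acceptor. Compound 1 offers no further number at this place, as its value is a limit: the limit of <= 80 mg/kg in this assay, at which 1 of the 3 values shown sits.

The compounds shown leave open whether this flat result would persist with a phenyl group carrying an amine or a carboxylic acid at this place. They also leave open whether an unsubstituted phenyl group would fall within the scatter of compound 3.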